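Cytotoxicity of three biaryl amides and an isobutoxy analogue

This account rests on a few compounds, and the source may have more. Where it says the series, first, only, none or still open, it means among the compounds named here.

The measured compounds:
Compound 1, `CCOC(=O)CCCCCOc1cccc(CN(C(=O)c2ccc(-c3cccc(N(C)C)c3)cc2)C(C)C)c1`, in an ADME assay on Raji cells (Homo sapiens) for cytotoxicity, read by CellTiter-Glo and resazurin assay, with a stated time of 72 h (on this read-out higher numbers stand for an effect only at larger amounts of compound and lower numbers for an effect already at smaller amounts), gives > 26000 nM.
Compound 2, `CCOC(=O)CCCCCOc1cccc(CN(C(=O)c2ccc(-c3cccc(NC(C)=O)c3)cc2)C(C)C)c1`, in this assay gives > 26000 nM.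
Compound 3, `CCOC(=O)CCCCCOc1cccc(CN(C(=O)c2ccc(-c3cccc(-c4ccccc4)c3)cc2)C(C)C)c1`, in this assay gives > 26000 nM.

Each of these three values is a limit of this assay, not a number, and all three sit at the same limit, (the limit of > 26000 nM in this assay, at which 3 of the 3 values shown sit). Compound 3 therefore stands nowhere distinguishable from compound 1 or compound 2: the step from compound 1 to compound 3 is a step that the two limits leave unreadable from compound 1 to compound 3, and the step from compound 2 to compound 3 is a step that the two limits leave unreadable from compound 2 to compound 3. The step from compound 1 to compound 2, a step that the two limits leave unreadable from compound 1 to compound 2, is unreadable for the same reason.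

Compound 4, `CCOC(=O)CCCCCOc1cccc(CN(C(=O)c2ccc(-c3cccc(OCC(C)C)c3)cc2)C(C)C)c1`, differs from compound 3 by isobutoxy in place of phenyl on an aromatic carbon. No measured step can be read in size, so none bears on the change in a readable way; the only fact at hand is that every measured compound, including compound 3, sits at the limit. Compound 4 is therefore expected to remain at or near that limit, with an expected step that the limit leaves unreadable from compound 3 to compound 4. The estimate for compound 4 in this assay is 30000 nM, ranging from 14000 nM to 80000 nM.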

Compound 4, half-maximal effective concentration: > 26000 nM
Compound 4: only a limit was reported; the forecaster's own chance of this, stated with the estimate: 85%; the middle value does not contradict the limit.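

In this assay compound 4 gives > 26000 nM, a limit and not a number. No step from compound 1, compound 2 or compound 3 to compound 4 can be read: the limit of > 26000 nM in this assay, at which 4 of the 4 values shown sit.

The compounds shown leave open whether dimethylamino, acetamido, phenyl and isobutoxy differ at all in this assay.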